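A few compounds are considered here, and "the series" means these few. Any claim that something is new, unique, unknown or untested is made for them only; others in the source may bear on it.

Measured compounds:
Compound 1, `CN1CCN(CC(=O)Nc2ccc(-c3nc(-c4ccccc4)c(-c4ccccc4)n3C)cc2)CC1`: 46.2%
Compound 2, `CCN1CCN(CC(=O)Nc2ccc(-c3nc(-c4ccccc4)c(-c4ccccc4)n3C)cc2)CC1`: 38.6%
Compound 3, `Cc1ccc(CN2CCN(CC(=O)Nc3ccc(-c4nc(-c5ccccc5)c(-c5ccccc5)n4C)cc3)CC2)cc1`: 31.5%

These three compounds share one core and differ only in the group sitting on a saturated chain carbon bound to an amine nitrogen in a ring. In a functional assay on MCF7 cells (Homo sapiens) for cytotoxicity, read by MTT assay, with a stated time of 24 h, tested at 32 ug/mL (on this read-out lower numbers stand for a weaker effect and higher numbers for a stronger effect at the one concentration tested), compound 3 gives the lowest of the three numbers. Its gap to compound 2 is small: a number 7.1 percentage points lower from compound 2 to compound 3 (within the scatter). Its gap to compound 1 is larger: a number 14.7 percentage points lower from compound 1 to compound 3 (beyond the scatter). The gap between compound 1 and compound 2 is again small: a number 7.6 percentage points lower from compound 1 to compound 2 (within the scatter).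

Compound 4, `COc1ccc(CN2CCN(CC(=O)Nc3ccc(-c4nc(-c5ccccc5)c(-c5ccccc5)n4C)cc3)CC2)cc1`, keeps the whole framework of compound 3 and alters one group on an aromatic carbon: methoxy in place of methyl on an aromatic carbon. Among the compounds with values here, none of the measured steps touches this aromatic carbon; all three alter the group on the saturated chain carbon instead, so they offer no direct guide to swapping methyl for methoxy. What they do show is that the numbers across this set move only over a modest span. Within the data shown here, with no measured step bearing on the change, the expected step of a number 0.5 percentage points higher from compound 3 to compound 4 (within the scatter) is none beyond the scatter. Compound 4 is therefore estimated at 32%, with a range from 20% to 46%.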

Compound 4, a percentage reported as activity, at one concentration (the size of the read-out at that concentration, not a potency): 17.7%
Estimate against measurement, compound 4: 14.3 percentage points above; measured number outside the range, below it.
By their numbers in this assay, from the lowest: compound 4; then compounds 3, 2 and 1 (each within the scatter of the next, the first and the last beyond it).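

In this assay, methoxy in place of methyl on an aromatic carbon, para to a large group, gives a number 13.8 percentage points lower from compound 3 to compound 4 (beyond the scatter) and shows that this ring position is not silent, since the swap from 4-methylbenzyl to 4-methoxybenzyl moves the number by about as much as a number 14.7 percentage points lower from compound 1 to compound 3 (beyond the scatter) did on the saturated chain carbon. The two longer comparisons, a number 20.9 percentage points lower from compound 2 to compound 4 (beyond the scatter) and a number 28.5 percentage points lower from compound 1 to compound 4 (beyond the scatter), place compound 4 beyond the scatter of all three earlier compounds, which makes it the weakest of the set at the one concentration tested. Nothing available here explains why this change lowers the number.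

The compounds shown leave open whether a fluorine, a chlorine or a hydroxyl on the same aromatic carbon would lower the number as methoxy does, and whether a longer chain such as ethoxy would lower it further. They also leave open whether methoxy on another carbon of this ring would give a similar result, and a single concentration cannot show how potency changes.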